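Oxazolylamino in Place of the Isoindolinone Lactam

This account rests on a few compounds, and the source may have more. Where it says the series, first, only, none or still open, it means among the compounds named here.

The series shares a core carrying a fluoro-substituted dihydrobenzofuranylmethylamino group. Compound 1 `CNC(=O)c1ccc(-c2cnc(NCc3c(F)ccc4c3CCO4)c3cn[nH]c(=O)c23)c(C)n1` and compound 2 `O=C1c2ccccc2CN1c1cnc(NCc2c(F)ccc3c2CCO3)n2cnnc12` were both measured in a functional assay on KARPAS-422 cells (Homo sapiens) for inhibition, read by luminescence and CellTiter-Glo, with a stated time of 14 days; a lower number here means a stronger inhibitor of growth, a higher number a weaker inhibitor of growth: compound 1 gives 13 nM, and compound 2 gives 19 nM. Compound 2 carries the higher of the two numbers, but the gap to compound 1 lies within the usual scatter, so neither compound is set apart from the other. Compound 3 `O=C1CC2(CC2)CN1c1cnc(NCc2c(F)ccc3c2CCO3)n2cnnc12` was run in this assay, yet for compound 3 the entry reads "not determined" (no result reported), so it adds nothing to the comparison.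

Compound 4 `CN(c1ncco1)c1cnc(NCc2c(F)ccc3c2CCO3)n2cnnc12` differs from compound 2 in one place: a group of 7 heavy atoms (4 carbon, 2 nitrogen, 1 oxygen; one five-membered aromatic ring with 2 hetero atoms) in place of a group of 10 heavy atoms (8 carbon, 1 nitrogen, 1 oxygen; one five-membered non-aromatic ring with 1 hetero atom, one six-membered aromatic ring of carbon only), on an aromatic carbon. Among the measured compounds shown here, no measured step of this kind is available among the compounds in hand. The lactam of compound 2 is exchanged for a smaller aromatic group, and he expects the number in this assay to rise modestly, by a step of a 2.4-fold higher number from compound 2 to compound 4 (0.37 log units; beyond the scatter) that may reach beyond the scatter. His estimate for compound 4 is 45 nM, with a range from 12 nM to 180 nM.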

Compound 4, concentration for 50% growth inhibition: 21 nM
The estimate for compound 4 lay 2.1-fold (0.33 log units) above the measured number; the range from low to high includes it.
By their numbers in this assay, from the lowest: compounds 1, 2 and 4 (each within the scatter of the next).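

Replacing the lactam group of compound 2 with methyl(1,3-oxazol-2-yl)amino on this aromatic carbon gives, in this assay, a 1.1-fold higher number from compound 2 to compound 4 (0.04 log units; within the scatter). Among the compounds shown here, this is the first step measured at this position, and it shows that a smaller group with a five-membered aromatic ring can stand here in place of the lactam and its six-membered aromatic ring of carbon only, with no change beyond the scatter. No measurement on hand explains why the two groups read alike.

The compounds shown leave open whether the oxazole ring is needed at all, or whether a plain dimethylamino group or a pyridine ring would give a similar number. For the compounds shown here, they also leave open what the methyl on the linking nitrogen contributes, since no compound carries a hydrogen there instead.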